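Acetamido to pyridinyl urea: a step from compound 2

A few compounds are considered here, and "the series" means these few. Any claim that something is new, unique, unknown or untested is made for them only; others in the source may bear on it.

Three compounds of the series carry a measured value in a functional assay on LNCaP cells (Homo sapiens) for cytotoxicity; on this read-out higher numbers stand for weaker inhibition and lower numbers for stronger inhibition. Compound 1 `c1cc2cc(-c3nc(N4CC5CCC(C4)O5)c4sccc4n3)ccc2[nH]1` gives 1350 nM. Compound 2 `CC(=O)Nc1ccc(-c2nc(N3CC4CCC(C3)O4)c3sccc3n2)cc1` gives 1700 nM, the highest number of the three; the gap to compound 1 lies within the scatter, so the two read as equivalent here. Compound 3 `CN1CCN(Cc2cc3nc(-c4ccc(NC(=O)NC5CC5)cc4)nc(N4CC5CCC(C4)O5)c3s2)CC1` gives 400 nM, a number beyond the scatter from compound 2; since compound 3 differs from compound 2 in more than one place, only the two values themselves can be set side by side.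

Compound 4 `O=C(Nc1ccncc1)Nc1ccc(-c2nc(N3CC4CCC(C3)O4)c3sccc3n2)cc1` has not been measured. It arises from compound 2 by one change: (pyridin-4-yl)amino in place of methyl on a carbonyl carbon. Among the measured compounds shown here, compound 3, the only member with a lower number than compound 2 beyond the scatter, also bears a carbamoylamino group, though with a further difference on the shared core as well, so the share of that group in the gap cannot be separated.

A downward step in this assay is expected from compound 2 to compound 4, moderate in size, a 2.4-fold lower number from compound 2 to compound 4 (0.39 log units; beyond the scatter). For the measured compounds named here, compound 3 at 400 nM is the only comparison available for that direction. Compound 4 is estimated at 700 nM, within a range from 250 nM to 2000 nM.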

Compound 4, half-maximal inhibitory concentration: 10 nM
For compound 4 the middle estimate is 70-fold (1.85 log units) above the measured one; measured number outside the range, below it.
By their numbers in this assay, from the lowest: compound 4; then compound 3; then compounds 1 and 2 (each within the scatter of the next).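

In this assay, the carbonyl carbon bearing the amide-type nitrogen turns out to be a highly sensitive place in the series: the exchange of methyl for (pyridin-4-yl)amino gives a 170-fold lower number from compound 2 to compound 4 (2.23 log units; beyond the scatter). Among the compounds shown here, the earlier compounds offered no one-place comparison, so this is the first step that can be assigned to a single change on an otherwise unchanged structure. It also shows that this carbonyl carbon can carry a far larger group, with seven heavy atoms and an aromatic ring entering where one carbon leaves, while the number falls rather than rises. No measurement at hand explains the size of the step.

The entering group adds the amino hydrogen and the pyridine ring together, so the share of each in the step remains unresolved. Also open, on these data alone, is whether pyridin-3-yl or plain phenyl in place of pyridin-4-yl would stay near the value of compound 4 at 10 nM, or whether the ring nitrogen and its place matter.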